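The source may hold more compounds than are shown below. What is called first, only, known or untested is meant among the compounds shown, and "the series" means these compounds.

Compound 1 `Cc1ccc(NN=C(c2nc3ccccc3[nH]2)c2nc3ccccc3[nH]2)cc1`: 10500 nM
Compound 2 `COc1ccc(NN=C(c2nc3ccccc3[nH]2)c2nc3ccccc3[nH]2)cc1`: 66500 nM

In a functional assay on HCT-116 cells (Homo sapiens) for cytotoxicity, read by MTT assay, with a stated time of 72 h (on this read-out lower numbers stand for stronger inhibition and higher numbers for weaker inhibition), compound 1 gives 10500 nM, while compound 2 gives 66500 nM. Within the data shown here, compound 2 thus stands at the higher of the two numbers seen so far; the only measured step between the two is a 6.3-fold higher number from compound 1 to compound 2 (0.80 log units; beyond the scatter). Compound 3 `Clc1ccc(NN=C(c2nc3ccccc3[nH]2)c2nc3ccccc3[nH]2)cc1` differs from compound 2 by chloro in place of methoxy on an aromatic carbon. Among the measured compounds shown here, no measured step exchanges chloro for methoxy, so the one measured step can guide only indirectly: it shows that replacing the group at this position moved the number well beyond the scatter in one direction, and that compound 1 with methyl sits markedly lower than compound 2. On that basis the step from compound 2 to compound 3 is expected to be a 3.3-fold lower number from compound 2 to compound 3 (0.52 log units; beyond the scatter). Compound 3 is therefore estimated at 20000 nM, with a likely range from 6000 nM to 70000 nM.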

Compound 3, half-maximal inhibitory concentration: 16800 nM
The estimate for compound 3 lay 1.2-fold (0.08 log units) above the measured number; the range from low to high includes it.
By their numbers in this assay, from the lowest: compounds 1 and 3 (each within the scatter of the next); then compound 2.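

In this assay, among these compounds, chloro in place of methoxy at this position gives a 4.0-fold lower number from compound 2 to compound 3 (0.60 log units; beyond the scatter), so methyl is no longer the only group that separates clearly from methoxy. Chloro in place of methyl gives a 1.6-fold higher number from compound 1 to compound 3 (0.20 log units; within the scatter), so these two groups cannot be told apart here. Among these three compounds, methoxy alone stands apart, with the highest number and so the weakest inhibition, though this pattern rests on just three groups at a single position.

No supporting measurement is available to say why methoxy stands apart. From the compounds shown here alone, whether an amine, a carboxylic acid or a longer chain at this position would group with methyl and chloro, stand with methoxy, or reach a number unlike any of the three remains open.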